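The compounds below may be only part of what the source reports. "The series", "measured", "known", "first", "only" and "open" are said of these compounds alone.

The compounds measured so far, with their numbers in a functional assay on cells (T-cell, Mus musculus, strain BALB/c) for inhibition, read by MTT assay, with stated times of 24 h and 72 h; a lower number here means a stronger inhibitor, a higher number a weaker inhibitor:

compound 1, `COc1cc(-c2nnc(SCc3ccc(Cl)cc3)o2)ccc1O`, gives 11100 nM
compound 2, `COc1cc(-c2nnc(SCc3ccc(F)cc3F)o2)ccc1O`, gives 9690 nM
compound 3, `COc1cc(-c2nnc(SCc3ccccc3Br)o2)ccc1O`, gives 17800 nM

All three share the same core and differ only in the halogen pattern on the ring attached to a saturated chain carbon bound to a sulfur. Compound 3 shows the highest of the three numbers, but both of its gaps, a 1.6-fold higher number from compound 1 to compound 3 (0.21 log units; within the scatter) and a 1.8-fold higher number from compound 2 to compound 3 (0.26 log units; within the scatter), fall within the scatter, so the three compounds cannot be told apart on these data. The step of a 1.1-fold lower number from compound 1 to compound 2 (0.06 log units; within the scatter) is likewise within the scatter.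

Compound 4, `COc1cc(-c2nnc(SCc3ccccc3)o2)ccc1O`, is not yet measured. It differs from compound 3 by hydrogen in place of bromo on an aromatic carbon, so the 2-bromophenyl becomes a plain phenyl. Going by the values given here, no measured step removes a halogen outright, but every measured swap between halogen patterns stayed within the scatter. The expected step is therefore a 1.4-fold lower number from compound 3 to compound 4 (0.14 log units; within the scatter), no change beyond the scatter. In this assay compound 4 is estimated at 13000 nM, with a range from 6000 nM to 30000 nM.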

Compound 4, half-maximal inhibitory concentration: 1250 nM
Compound 4: middle estimate off by 10-fold (1.02 log units), on the high side; the whole stated range lies above it.
By their numbers in this assay, from the lowest: compound 4; then compounds 2, 1 and 3 (each within the scatter of the next).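

In this assay, the halogen patterns on this ring looked interchangeable, yet replacing bromo with hydrogen gives a 14-fold lower number from compound 3 to compound 4 (1.15 log units; beyond the scatter), and replacing chloro with hydrogen gives an 8.9-fold lower number from compound 1 to compound 4 (0.95 log units; beyond the scatter). Going to phenyl from 2,4-difluorophenyl likewise gives a 7.8-fold lower number from compound 2 to compound 4 (0.89 log units; beyond the scatter), so among these four compounds the real divide lies between the halogen-free ring and the three halogen-bearing rings, not among the halogen patterns. No measurement at hand accounts for the size of these steps.

The compounds shown leave open whether a methyl group or an amine on this ring would give a number like that of compound 4 or like those of the halogen-bearing compounds. They also leave open whether the low number of compound 4 would survive a longer chain between the sulfur and the phenyl.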